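The source may report more compounds than this note shows. Statements on the series, on what has been measured and on what is new or still open speak of the compounds shown alone.

Compound 1, `CCn1c(C(=O)N[C@H](C)C(=O)OC)ccc1C(CC)(CC)c1ccc(OCS(=O)(=O)c2ccccc2)c(C)c1`, in a functional assay on PC-3 cells (Homo sapiens) for antiproliferative activity, read by MTT assay, with a stated time of 24 h; on this read-out higher numbers stand for weaker inhibition and lower numbers for stronger inhibition: > 50000 nM, a limit of the assay.
Compound 2, `CCn1c(C(=O)NCCNC(=O)OC(C)(C)C)ccc1C(CC)(CC)c1ccc(OCS(=O)(=O)c2ccccc2)c(C)c1`, in this assay: > 50000 nM, again a limit of the assay.
Compound 3, `CCn1c(C(=O)NCCO)ccc1C(CC)(CC)c1ccc(OCS(=O)(=O)c2ccccc2)c(C)c1`, in this assay: 17700 nM.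

Compound 3 is the only one of the three with a number; the other two sit at the limit of > 50000 nM in this assay, at which 2 of the 3 values shown sit. The move from compound 1 to compound 3 reads an at least 2.8-fold lower number from compound 1 to compound 3 (0.45 log units; beyond the scatter), and from compound 2 to compound 3 it reads an at least 2.8-fold lower number from compound 2 to compound 3 (0.45 log units; beyond the scatter), so replacing either of the bulkier amide substituents with the 2-hydroxyethyl group brought the value down into the measurable range.

Compound 4, `CCn1c(C(=O)NCCCO)ccc1C(CC)(CC)c1ccc(OCS(=O)(=O)c2ccccc2)c(C)c1`, has not been measured. It differs from compound 3 by hydroxymethyl in place of hydroxy on a saturated chain carbon, two bonds along the chain from an amide-type nitrogen. The measured steps touch the same position, but they exchange a hydroxy for a larger carbamate or ester-bearing group, whereas here the chain is simply lengthened by one carbon with the hydroxy kept. For the measured compounds named here, none of the measured steps speaks directly to such a lengthening, so in this assay no step beyond the scatter is expected: the estimated move is a 1.0-fold higher number from compound 3 to compound 4 (0.01 log units; within the scatter). Compound 4 is therefore expected to give about 18000 nM, within 7000 nM to 45000 nM.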

Compound 4, half-maximal inhibitory concentration: 11300 nM
Estimate against measurement, compound 4: 1.6-fold (0.20 log units) above; measured number inside the range.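

In this assay, the step from 2-hydroxyethyl to 3-hydroxypropyl reads a 1.6-fold lower number from compound 3 to compound 4 (0.19 log units; within the scatter), so adding one carbon to the chain while keeping the hydroxy does not separate the two compounds beyond the scatter. The earlier compounds shown here could not show this, as their steps at this position exchanged the hydroxy-bearing chain for larger groups and left chain length untested. The 3-hydroxypropyl group also stands clear of the two substituents without a hydroxy, with an at least 4.4-fold lower number from compound 2 to compound 4 (0.64 log units; beyond the scatter) and an at least 4.4-fold lower number from compound 1 to compound 4 (0.64 log units; beyond the scatter), and both of these steps are only bounds, as compound 1 and compound 2 each sit at a limit of the assay: the limit of > 50000 nM in this assay, at which 2 of the 4 values shown sit.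

Still open, going by these compounds, is whether a 4-hydroxybutyl chain would keep the value in the same range, and whether an amine or a carboxylic acid in place of the hydroxy on the 3-hydroxypropyl chain would do so. Also open, on these data alone, is how much of the gap to compound 1 and compound 2 belongs to the hydroxy itself rather than to the size of the groups it replaces.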